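Tolerated at the Limit: A New Group on the Ring Nitrogen

The compounds below may be only part of what the source reports. "The series", "measured", "known", "first", "only" and "open" are said of these compounds alone.

In an ADME assay on MT2 cells (Homo sapiens) for cytotoxicity, read by XTT assay, with a stated time of 4 days (a higher number here means that more compound is tolerated, a lower number that less compound is tolerated), compound 2 `Cc1ccc(-c2c3c(nc(C)c2[C@H](OC(C)(C)C)C(=O)O)CCN(c2ccccc2)C3)cc1` gives > 40000 nM as a limit of the assay, not a number. Compound 1 `Cc1ccc(-c2c3c(nc(C)c2[C@H](OC(C)(C)C)C(=O)O)CCN(CCCc2ccccc2)C3)cc1` gives > 40000 nM as a limit too. Compound 3 `Cc1nc2c(c(-c3cc(F)c4c(c3C)CCCO4)c1[C@H](OC(C)(C)C)C(=O)O)CN(CCCc1ccccc1)CC2` also gives > 40000 nM as a limit. Compound 2 thus stands with the other two, with the limit of > 40000 nM in this assay, at which 3 of the 3 values shown sit, and no number to rank them.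

Compound 4 `Cc1ccc(-c2c3c(nc(C)c2[C@H](OC(C)(C)C)C(=O)O)CCN(C(=O)CCc2ccccc2)C3)cc1` is still unmeasured. It carries phenethylcarbonyl in place of phenyl on an amine nitrogen in a ring.

Going by the values given here, two measured steps bear on this change. The closer one is a step that the two limits leave unreadable from compound 1 to compound 2 with phenyl in place of 3-phenylpropyl on an amine nitrogen in a ring. The other is a step that the two limits leave unreadable from compound 1 to compound 3 on an aromatic carbon. Neither has a readable size, and neither step took a compound off the limit.

With the limit of compound 2 at > 40000 nM as the starting point, no step beyond the scatter is expected in this assay in either direction. The estimate for the step is a number no higher from compound 2 to compound 4 (the limit leaves the size open) and it carries the same uncertainty. Compound 4 is expected at about 40000 nM with an estimated range of 25000 nM to 64000 nM and will most likely be reported as a limit again.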

Compound 4, half-maximal cytotoxic concentration: > 40000 nM
Compound 4: a limit, no number (the forecaster's own chance of this, stated with the estimate: 85%); the middle value sits exactly at the limit.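

In this assay compound 4 gives > 40000 nM, a limit and not a number, so its steps from compound 1 and compound 2 cannot be read. The compounds now stand together: the limit of > 40000 nM in this assay, at which 4 of the 4 values shown sit.

The compounds shown leave open how much of each is tolerated, and whether any change to the shared core would give a readable number.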